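Amide-nitrogen aryl swap in the catechol ether amide series

This account rests on a few compounds, and the source may have more. Where it says the series, first, only, none or still open, it means among the compounds named here.

Compound 2 `COc1ccc(C(=O)Nc2c(Br)cncc2Br)cc1OC1CCCC1` is the stronger of the two measured compounds in an assay on isolated protein for inhibition of phosphodiesterase 4A (Sus scrofa); on this read-out higher numbers stand for weaker inhibition and lower numbers for stronger inhibition: compound 2 gives 7 nM, and the nearest measured compound, compound 1 `COc1ccc(C(=O)Nc2ccccc2Br)cc1OC1CCCC1`, gives 130 nM. Among the compounds with values here, the only measured step on this read-out is a 19-fold lower number from compound 1 to compound 2 (1.27 log units; beyond the scatter), which exchanged the aryl group on the amide nitrogen and is beyond the scatter.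

Compound 3 `COc1ccc(C(=O)Nc2ncccc2C)cc1OC1CCCC1` is not yet measured. The change from compound 2 is 3-methylpyridin-2-yl in place of 3,5-dibromopyridin-4-yl on an amide-type nitrogen. Both bromines of compound 2 leave together with the ring they sit on, and a methyl-bearing pyridinyl arrives in their place.

Within the data shown here, the single step that bears on this is the one from compound 1 to compound 2, which gained strongly on taking up the dibrominated pyridinyl. Removing that group again in compound 3 is expected to give back part or all of that gain, so a step upward in this assay, beyond the scatter, is expected, estimated at a 17-fold higher number from compound 2 to compound 3 (1.23 log units; beyond the scatter). Compound 3 is therefore estimated at 120 nM, with a range from 30 nM to 500 nM.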

Compound 3, half-maximal inhibitory concentration: 3100 nM
Compound 3: the middle estimate sits 26-fold (1.41 log units) below what was measured, outside the stated range (above it).
By their numbers in this assay, from the lowest: compound 2; then compound 1; then compound 3.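

In this assay, the amide-type nitrogen proves far more demanding than the first pair suggested: a 440-fold higher number from compound 2 to compound 3 (2.65 log units; beyond the scatter), although the leaving and entering groups are both six-membered aromatic rings with 1 hetero atom and the counts of hydrogen-bond donors and acceptors stay the same. The new group does not merely fall back towards the phenyl compound either, since a 24-fold higher number from compound 1 to compound 3 (1.38 log units; beyond the scatter), which makes compound 3 the weakest of the three and shows that a pyridinyl ring on this nitrogen does not by itself carry the strength of compound 2. The compounds offer no independent measurement that could account for this loss.

The step from 3,5-dibromopyridin-4-yl to 3-methylpyridin-2-yl changes the substituents and the point of attachment of the ring together, so the compounds shown do not separate these two changes. Groups such as 3-methylpyridin-4-yl, 3-bromopyridin-2-yl or 3,5-dichloropyridin-4-yl on the same nitrogen would show how much of the span follows the attachment point and how much follows the halogens.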